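Chlorinated lactones: hydroxyphenyl to ethylphenyl exchange

The source may report more compounds than this note shows. Statements on the series, on what has been measured and on what is new or still open speak of the compounds shown alone.

Measured so far:
compound 1 `O=C1OC[C@H](Cc2ccccc2)[C@H]1Cc1cc(Cl)cc(Cl)c1`: 23000 nM
compound 2 `CCCCOc1ccc(/C=C2/C(=O)OC[C@@H]2Cc2ccccc2)cc1`: a limit, > 100000 nM
compound 3 `O=C1OC[C@H](Cc2ccccc2O)[C@H]1Cc1ccc(Cl)c(Cl)c1`: 33000 nM

In a functional assay on HL-60 cells (Homo sapiens) for cytotoxicity, read by WST assay, with a stated time of 48 h (on this read-out lower numbers stand for an effect already at smaller amounts and higher numbers for an effect only at larger amounts of compound), compound 3 gives 33000 nM and compound 1 gives 23000 nM; the gap between these two numbers lies within the scatter, so neither can be set apart from the other. Compound 2 is reported only as a limit of this assay, > 100000 nM, and not as a number. the limit of > 100000 nM in this assay, at which 1 of the 3 values shown sits, is the edge at which that value sits.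

Compound 4 `CCc1ccc(C[C@H]2COC(=O)[C@@H]2Cc2ccc(Cl)c(Cl)c2)cc1` has not yet been measured in this assay. Compared with compound 3 it carries 4-ethylphenyl in place of 2-hydroxyphenyl on a saturated chain carbon bound to a saturated ring carbon.

For the measured compounds named here, no pair of measured compounds differs in one place only, so no measured step supports a forecast. On the numbers at hand the change from compound 3 to compound 4 is expected to be small, within the scatter or a modest move toward a lower number, and the estimated step is a 1.3-fold lower number from compound 3 to compound 4 (0.12 log units; within the scatter). Compound 4 is therefore estimated at 25000 nM in this assay, with a range from 8000 nM to 80000 nM.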

Compound 4, half-maximal effective concentration: 16000 nM
Estimate against measurement, compound 4: 1.6-fold (0.19 log units) above, and the stated range covers the measured number.
By their numbers in this assay, from the lowest: compounds 4, 1 and 3 (each within the scatter of the next, the first and the last beyond it). At a limit, above all of these: compound 2.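

For the compounds shown here, exchanging 2-hydroxyphenyl for 4-ethylphenyl on a saturated chain carbon bound to a saturated ring carbon gives, in this assay, a 2.1-fold lower number from compound 3 to compound 4 (0.31 log units; beyond the scatter), a modest change and the first step that alters one place only. At this place, the cytotoxic effect therefore persists with a group counted as having no hydrogen-bond donor or acceptor, so neither the hydroxyl nor its donor is required for a number in this range. No measurement available here bears on why the number moves.

A single step cannot separate the loss of the hydroxyl from the arrival of the ethyl, or show how much depends on the substituent's ring position. Going by these compounds, whether an amine, a carboxylic acid or a longer chain in this place would lower the number further remains open.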